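The source may report more compounds than this note shows. Statements on the series, on what has been measured and on what is new or still open speak of the compounds shown alone.

The four compounds here share one core and differ only in the small groups on its outer aromatic rings. Compound 1 `Oc1ccc(-c2cc(-c3ccccc3C(F)(F)F)cc(-c3cccc(O)c3)n2)cc1` gives 17400 nM in a functional assay on HeLa cells (Homo sapiens) for inhibition; on this read-out lower numbers stand for stronger inhibition and higher numbers for weaker inhibition. Compound 2 `Oc1ccc(-c2cc(-c3ccccc3C(F)(F)F)cc(-c3ccc(O)cc3)n2)cc1` reaches only the limit > 50000 nM in this assay, a boundary of what the assay can report rather than a number. Compound 3 `Oc1ccc(-c2cc(-c3ccc(C(F)(F)F)cc3)cc(-c3ccc(O)cc3)n2)cc1` likewise sits at the limit > 50000 nM in this assay. The step of an at least 2.8-fold higher number from compound 1 to compound 2 (0.45 log units; beyond the scatter) is thus at least modest, whereas the step that the two limits leave unreadable from compound 2 to compound 3 cannot be read in size, because both values rest on (the limit of > 50000 nM in this assay, at which 2 of the 3 values shown sit).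

Compound 4 `Oc1ccc(-c2cc(-c3ccccc3OC(F)(F)F)cc(-c3ccc(O)cc3)n2)cc1` has not yet been measured. It differs from compound 2 by trifluoromethoxy in place of trifluoromethyl on an aromatic carbon. Going by the values given here, none of the measured steps touches this group, so no measured step bears directly on the change; the nearest comparison, the one moving the trifluoromethyl group between compound 2 and compound 3, is itself unreadable. With compound 2 already beyond the reach of this assay, the most likely outcome is that compound 4 also gives no number. The expected value for compound 4 in this assay is 60000 nM, with a range from 20000 nM to 200000 nM. The expected step is a step that the limit leaves unreadable from compound 2 to compound 4, not beyond the scatter.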

Compound 4, half-maximal inhibitory concentration: 44600 nM
Compound 4: middle estimate off by 1.3-fold (0.13 log units), on the high side; the range from low to high includes it.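

Going by these compounds alone, the swap of trifluoromethyl for trifluoromethoxy, on an aromatic carbon ortho to a large group, is the first change here that touches this substituent itself rather than moving it, and in this assay compound 4 gives 44600 nM, a readable number. This shows that a compound with 4-hydroxyphenyl on both sides of the shared core can still register on this read-out, which neither earlier compound of that kind did, although the change amounts only to an at least 1.1-fold lower number from compound 2 to compound 4 (0.04 log units; that floor lies within the scatter), so the data show no more than a floor for its size. Compound 2 stands at > 50000 nM, which is a limit and not a number.

As far as these compounds go, the true size of this step stays unknown, and the step that moves trifluoromethyl from compound 2 to compound 3 cannot be read either, because each rests on a limit: the limit of > 50000 nM in this assay, at which 2 of the 4 values shown sit. Also open, from the compounds shown here alone, is what other groups at this place, such as methoxy, chlorine or an amine, would do, and whether trifluoromethoxy would give a similar result alongside the 3-hydroxyphenyl group of compound 1.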